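The compounds below may be only part of what the source reports. "The series", "measured", "known", "first", "only" and "open" are said of these compounds alone.

Compound 1 `CO[C@@H]1CC=C2N(c3ccc([N+](=O)[O-])cc3)C(=O)C[C@]2(c2ccccc2)O1` gives 6300 nM in a functional assay on SK-BR-3 cells (Homo sapiens) for cytotoxicity, read by sulforhodamine B assay, with a stated time of 48 h (a higher number here means a weaker inhibitor, a lower number a stronger inhibitor), the highest of the two numbers in hand; compound 2 `COc1cc(OC)cc(N2C(=O)C[C@]3(c4ccccc4)O[C@H](OC)CC=C23)c1` gives 1100 nM in this assay, a gap that lies beyond the usual scatter. Compound 3 `CO[C@@H]1CC=C2N(c3cc(Cl)cc(Cl)c3)C(=O)C[C@]2(c2ccccc2)O1` differs from compound 1 by 3,5-dichlorophenyl in place of 4-nitrophenyl on an amide-type nitrogen in a ring. Going by the values given here, no measured pair shows this change, so its effect cannot be read from the data. Compound 3 is expected to land near 3500 nM, within 900 nM to 14000 nM. The step of a 1.8-fold lower number from compound 1 to compound 3 (0.26 log units; within the scatter) is thus estimated as a modest move toward stronger inhibition, not clearly beyond the scatter.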

Compound 3, half-maximal inhibitory concentration: 6540 nM
The estimate for compound 3 lay 1.9-fold (0.27 log units) below the measured number, within the range that was stated.
By their numbers in this assay, from the lowest: compound 2; then compounds 1 and 3 (each within the scatter of the next).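

In this assay, going by these compounds alone, 3,5-dichlorophenyl in place of 4-nitrophenyl on the amide-type nitrogen in a ring gives a 1.0-fold higher number from compound 1 to compound 3 (0.02 log units; within the scatter) and so offers the first reading of a change at this position. Here, a group with hydrogen-bond acceptors and one with none cannot be told apart. No supporting measurement bears on this outcome. The compounds shown leave open whether a phenyl ring carrying an amine or a carboxylic acid would shift the number. They also leave open what a cyclohexyl group or a longer alkyl chain on that nitrogen would do.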